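From 4-fluorophenyl to 2-cyanophenyl

The compounds below may be only part of what the source reports. "The series", "measured", "known", "first", "only" and "open" are said of these compounds alone.

Values in a toxicity assay on MT4 cells (Homo sapiens) for cytotoxicity, read by MTT assay (on this read-out lower numbers stand for higher toxicity in this test and higher numbers for lower toxicity in this test), so far:
Compound 1 `Cc1cc(-c2cccc(F)c2)ccc1Oc1cc(N)nc(Nc2ccc(C#N)cc2)n1` gives 11300 nM
Compound 2 `Cc1cc(-c2ccc(F)cc2)ccc1Oc1cc(N)nc(Nc2ccc(C#N)cc2)n1` gives 20100 nM

Among the compounds with values here, compound 2 stands within the scatter of compound 1, the only other measured compound (a 1.8-fold higher number from compound 1 to compound 2 (0.25 log units; within the scatter)). Compound 3 `Cc1cc(-c2ccccc2C#N)ccc1Oc1cc(N)nc(Nc2ccc(C#N)cc2)n1` carries 2-cyanophenyl in place of 4-fluorophenyl on an aromatic carbon. Within the data shown here, only that one measured step bears on this change, and it did not involve a nitrile, so the guide is weak. It was small, so no step beyond the scatter is expected in this assay, in either direction. The expected step is small (a 1.3-fold lower number from compound 2 to compound 3 (0.13 log units; within the scatter)). For compound 3 the estimate is 15000 nM, with an expected range from 5000 nM to 40000 nM and nothing firmer to go on.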

Compound 3, half-maximal cytotoxic concentration: 28600 nM
The estimate for compound 3 lay 1.9-fold (0.28 log units) below the measured number, within the range that was stated.
By their numbers in this assay, from the lowest: compounds 1, 2 and 3 (each within the scatter of the next, the first and the last beyond it).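

In this assay, 2-cyanophenyl can replace 4-fluorophenyl on this aromatic carbon with a result that stays within the scatter (a 1.4-fold higher number from compound 2 to compound 3 (0.15 log units; within the scatter)). Against 3-fluorophenyl, the same group gives the first step in this series beyond the scatter, though only a modest one (a 2.5-fold higher number from compound 1 to compound 3 (0.40 log units; beyond the scatter)), so a nitrile-bearing group is compatible with this position without a lower number. Nothing available explains either step. From the compounds shown here alone, it remains open how an amine or a carboxylic acid on this aromatic ring would compare, and whether 4-cyanophenyl would match 2-cyanophenyl.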